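The source may report more compounds than this note shows. Statements on the series, on what has been measured and on what is new or still open speak of the compounds shown alone.

In a functional assay on HL-60 cells (Homo sapiens) for inhibition, read by MTT assay, with a stated time of 48 h, tested at 10 uM (a higher number here means more inhibition of growth at the concentration tested, a lower number less inhibition of growth), compound 1 `Cc1cc(=O)c2c(O)cc(OCc3ccccc3)c([C@H]3CCN(C)C[C@H]3O)c2o1` gives 24% and compound 2 `Cc1cc(=O)c2c(O)c(CN3CCCC3CO)c(O)c([C@H]3CCN(C)C[C@H]3O)c2o1` gives 33%. These two values lie within the scatter of each other, so compound 2 stands level with compound 1 on the numbers available. Compound 3 `Cc1cc(=O)c2c(O)c(CN3CC(O)CC3C(=O)O)c(O)c([C@H]3CCN(C)C[C@H]3O)c2o1` differs from compound 2 by 2-carboxy-4-hydroxypyrrolidin-1-yl in place of 2-(hydroxymethyl)pyrrolidin-1-yl on a saturated chain carbon bound to an aromatic carbon, with 2-carboxy-4-hydroxypyrrolidin-1-yl in place of 2-(hydroxymethyl)pyrrolidin-1-yl. Among the measured compounds shown here, no measured pair shows this change, so the expectation in this assay is tentative: a small downward step, not beyond the scatter, is estimated (a number 8 percentage points lower from compound 2 to compound 3 (within the scatter)). For compound 3 the estimated value is 25%, with an expected range of 8% to 42%.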

Compound 3, percent growth inhibition at one concentration: 28%
For compound 3 the middle estimate is 3 percentage points below the measured one, within the range that was stated.
By their numbers in this assay, from the lowest: compounds 1, 3 and 2 (each within the scatter of the next).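

At this place, on a saturated chain carbon bound to an aromatic carbon, 2-carboxy-4-hydroxypyrrolidin-1-yl in place of 2-(hydroxymethyl)pyrrolidin-1-yl gives in this assay the step of a number 5 percentage points lower from compound 2 to compound 3 (within the scatter) and so the two pyrrolidine groups are not separated at this single concentration. The added carboxy and hydroxy substituents on the ring therefore leave the reading level here. No measured property on hand accounts for this step.

Still open, on these data alone, is how a piperidine ring or an open-chain dimethylamino group would read on the same carbon. As far as these compounds go, whether the carboxylic acid or the ring hydroxyl alone would read the same also remains open.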